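From sulfonyl ester to hydroxymethyl: a step expected quiet

This account rests on a few compounds, and the source may have more. Where it says the series, first, only, none or still open, it means among the compounds named here.

The measured compounds in a functional assay on SW1573 cells (Homo sapiens) for antiproliferative activity, read by sulforhodamine B assay, with a stated time of 48 h (a higher number here means a weaker inhibitor of growth, a lower number a stronger inhibitor of growth), are these.
Compound 1 `COc1cc(C2=NOC(CO[C@@H]3O[C@H](CSc4ncn[nH]4)[C@H]4OC5(CCCC5)O[C@@H]34)C2)cc(OC)c1OC` gives > 100000 nM, a limit of the assay.
Compound 2 `COc1cc(-c2nc(CO[C@@H]3O[C@H](CSc4ncn[nH]4)[C@H]4OC5(CCCC5)O[C@@H]34)no2)cc(OC)c1OC` gives 36000 nM.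
Compound 3 `Cc1ccc(S(=O)(=O)OC[C@H]2O[C@@H](OCc3noc(-c4ccc([N+](=O)[O-])cc4)n3)[C@@H]3OC4(CCCC4)O[C@@H]32)cc1` gives > 100000 nM, a limit of the assay.

Compound 3 therefore stands at the limit of > 100000 nM in this assay, at which 2 of the 3 values shown sit. Only compound 2 returns a number, and a weak one. Compound 4 `O=[N+]([O-])c1ccc(-c2nc(CO[C@@H]3O[C@H](CO)[C@H]4OC5(CCCC5)O[C@@H]34)no2)cc1` is the untested partner of compound 3; the change is hydrogen in place of (4-methylphenyl)sulfonyl on an oxygen on a saturated carbon. Going by the values given here, no step between measured compounds is available, so the expectation rests on the weakness of all three and on the limit at which compound 3 sits. The step that the limit leaves unreadable from compound 3 to compound 4 is expected to lie within the scatter, most likely again as a limit. For compound 4 the estimate is 150000 nM, with a range from 40000 nM to 600000 nM.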

Compound 4, concentration for 50% growth inhibition: 27000 nM
Beside the measured number, compound 4's estimate is 5.6-fold (0.74 log units) above it; measured number outside the range, below it.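

In this assay, hydrogen in place of (4-methylphenyl)sulfonyl on an oxygen on a saturated carbon gives an at least 3.7-fold lower number from compound 3 to compound 4 (0.56 log units; beyond the scatter), so this position is not silent and hydroxymethyl here returns a measurable, though weak, number. The true size of the step stays unknown because one end of it is a limit: the limit of > 100000 nM in this assay, at which 2 of the 4 values shown sit.

On these data alone, whether another group at this position, such as an amine or a carboxylic acid, would move the number further remains open. So does whether the same step would appear without the 4-nitrophenyl group of compound 4.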